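The source may report more compounds than this note shows. Statements on the series, on what has been measured and on what is new or still open speak of the compounds shown alone.

In an ADME assay on the whole organism with Oryza sativa as the target, tested at 1 uM (a lower number here means a stronger effect, a higher number a weaker effect of the compound at the concentration tested), compound 1 `Cc1ccccc1NC(=O)N[C@H](C)c1ccccc1` gives 100%, compound 2 `Cc1ccc(NC(=O)N[C@H](C)c2ccccc2)cc1` gives 98%, and compound 3 `Cc1ccc(NC(=O)N[C@@H](C)c2ccccc2)cc1` gives 99%. The three numbers sit close together, and the gaps between them are within the usual scatter, so none of them can be told apart from the others on this evidence. Within the data shown here, the only step measured so far, a number 1 percentage points higher from compound 2 to compound 3 (within the scatter), rests on (the fact that compounds 2 and 3 differ only in the configuration as drawn), and it changes nothing beyond the scatter.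

Compound 4 `CCCc1ccc(NC(=O)N[C@H](C)c2ccccc2)cc1` is not yet measured in this assay. It differs from compound 2 by ethyl in place of hydrogen on a saturated chain carbon bound to an aromatic carbon. Among the measured compounds shown here, no measured step bears on this kind of change; the one known step swaps a configuration and is of no help here, so the expectation can only lean on the level at which compound 2 and its two companions already stand. The step of a number 1 percentage points lower from compound 2 to compound 4 (within the scatter) is therefore expected to stay within the scatter. Compound 4 is expected to give 97%, with a range from 85% to 103%.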

Compound 4, a percentage reported as activity, at one concentration (the size of the read-out at that concentration, not a potency): 31%
The estimate for compound 4 lay 66 percentage points above the measured number; measured number below the stated range.
By their numbers in this assay, from the lowest: compound 4; then compounds 2, 3 and 1 (each within the scatter of the next).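

In this assay, compounds 2 and 3 showed only that the drawn configuration leaves the number within the scatter, while lengthening methyl to propyl gives a number 67 percentage points lower from compound 2 to compound 4 (beyond the scatter). Among these compounds, this is the first step here beyond the scatter, so the group at this place, on a saturated chain carbon bound to an aromatic carbon, does matter for the read-out at the concentration tested. The one fact at hand concerns configuration alone and does not bear on this step.

Going by these compounds, with only methyl and propyl compared at this place, it stays open whether the number keeps falling with a longer chain such as butyl, and how a branched isopropyl or a chain carrying an amine would behave. On these data alone, it is also open whether, with propyl in place, the opposite configuration would still make no difference.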